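Solubility notes on the fused-core series: compound 3

The source may hold more compounds than are shown below. What is called first, only, known or untested is meant among the compounds shown, and "the series" means these compounds.

Measured so far:
compound 1 `O=C1c2ccccc2CN1c1cnc(NCc2c(F)ccc3c2CCO3)n2cnnc12` — 4000 nM
compound 2 `CC1(C)CC(=O)N(c2cnc(NCc3c(F)ccc4c3CCO4)n3cnnc23)C1` — 57000 nM

In a physicochemical assay for solubility, read by LC-MS, in phosphate buffer, with a stated time of 24 h, at pH 7.4 (on this read-out lower numbers stand for lower solubility and higher numbers for higher solubility), compound 2 gives 57000 nM and stands highest of the two numbers; compound 1, the nearest, gives 4000 nM. For the measured compounds named here, the only measured step, a 14-fold higher number from compound 1 to compound 2 (1.15 log units; beyond the scatter), is large and shows that the group on this aromatic carbon moves solubility strongly. Compound 3 `O=C(Nc1cnc(NCc2c(F)ccc3c2CCO3)n2cnnc12)c1cccnc1` carries ((pyridin-3-yl)carbonyl)amino in place of 4,4-dimethyl-2-oxopyrrolidin-1-yl on an aromatic carbon. Going by the values given here, no measured step swaps a lactam for an amide here, so the direction rests on that single step alone. A modest downward step a 2.9-fold lower number from compound 2 to compound 3 (0.45 log units; beyond the scatter) from compound 2 is expected, with wide uncertainty. Compound 3 is estimated at 20000 nM, range 4000 nM to 70000 nM.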

Compound 3, solubility: 12000 nM
Compound 3: middle estimate off by 1.7-fold (0.22 log units), on the high side; measured number inside the range.
By their numbers in this assay, from the lowest: compound 1; then compound 3; then compound 2.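

In this assay the change from 4,4-dimethyl-2-oxopyrrolidin-1-yl to ((pyridin-3-yl)carbonyl)amino on this aromatic carbon gives a 4.8-fold lower number from compound 2 to compound 3 (0.68 log units; beyond the scatter) as its read-out. Against the group of compound 1, the same ((pyridin-3-yl)carbonyl)amino gives a 3.0-fold higher number from compound 1 to compound 3 (0.48 log units; beyond the scatter) on the same shared core. The three groups therefore separate into three distinct levels, and the two groups with an aromatic ring both stand lower than 4,4-dimethyl-2-oxopyrrolidin-1-yl. The compounds shown leave open whether the amide hydrogen or the pyridine ring carries the step, and how a simple amine or a carboxylic acid on this aromatic carbon would read. No supporting data here bear on the reason for this order.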